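The source may hold more compounds than are shown below. What is called first, only, known or untested is meant among the compounds shown, and "the series" means these compounds.

Measured in a functional assay on HeLa cells (Homo sapiens) for inhibition, read by CCK-8 assay, with a stated time of 48 h; on this read-out higher numbers stand for weaker inhibition and lower numbers for stronger inhibition:
- compound 1 `COc1cc(-c2ccnc3cc(-c4ccc(C)c(C)c4)nn23)cc(OC)c1OC` gives 241 nM
- compound 2 `COc1cc(-c2ccnc3cc(-c4cn(C)c5ccccc45)nn23)cc(OC)c1OC` gives 399 nM

Compound 2 can be compared only with compound 1, and the two lie within the scatter of each other. In compound 3 `COc1cc(-c2ccnc3cc(-c4ccc(N(C)C)cc4)nn23)cc(OC)c1OC`, 4-(dimethylamino)phenyl stands in place of 1-methyl-1H-indol-3-yl on an aromatic carbon: 4-(dimethylamino)phenyl in place of 1-methyl-1H-indol-3-yl on an aromatic carbon. Among the measured compounds shown here, one measured step bears on this, an exchange of groups on that same carbon: a 1.7-fold higher number from compound 1 to compound 2 (0.22 log units; within the scatter). A step beyond the scatter in this assay is therefore not expected, and these data favour no clear direction. The expected step is a 1.3-fold lower number from compound 2 to compound 3 (0.11 log units; within the scatter). For compound 3 the estimated value is 310 nM, with an expected range from 110 nM to 850 nM.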

Compound 3, half-maximal inhibitory concentration: 378 nM
Compound 3: the middle estimate sits 1.2-fold (0.09 log units) below what was measured, within the range that was stated.
By their numbers in this assay, from the lowest: compounds 1, 3 and 2 (each within the scatter of the next).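

In this assay, the exchange at this carbon now covers three groups, and neither new step leaves the scatter: (a 1.1-fold lower number from compound 2 to compound 3 (0.02 log units; within the scatter)) and (a 1.6-fold higher number from compound 1 to compound 3 (0.20 log units; within the scatter)). The position thus accepts a dimethylamino-bearing phenyl, a dimethylphenyl and a fused 1-methyl-1H-indol-3-yl without a separable difference among compounds 1, 2 and 3. No supporting evidence is available to explain this.

The compounds shown leave open whether a carboxylic acid on the phenyl ring or a morpholine in place of the aromatic group would give a step beyond the scatter.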